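A few compounds are considered here, and "the series" means these few. Any claim that something is new, unique, unknown or untested is made for them only; others in the source may bear on it.

Compound 1 `Cc1cn([C@@H]2C[C@H](O)[C@@H](CNC(=O)Nc3ccc(Cl)cc3)O2)c(=O)[nH]c1=O` in an ADME assay on MRC5 cells (Homo sapiens) for cytotoxicity (on this read-out lower numbers stand for higher toxicity in this test and higher numbers for lower toxicity in this test), gives > 50000 nM, which is a limit of the assay.
Compound 2 `Cc1cn([C@@H]2C[C@H](O)[C@@H](CNC(=O)Nc3ccc(Br)cc3)O2)c(=O)[nH]c1=O` in this assay gives > 50000 nM, also a limit.
Compound 3 `Cc1cn([C@@H]2C[C@H](O)[C@@H](CNC(=O)Nc3ccc(C(C)(C)C)cc3)O2)c(=O)[nH]c1=O` in this assay gives > 50000 nM, also a limit.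

Compound 1 therefore stands at the limit of this assay, and the two other measured compounds stand at the same limit (the limit of > 50000 nM in this assay, at which 3 of the 3 values shown sit). The steps that change the group on the aromatic ring, a step that the two limits leave unreadable from compound 1 to compound 2, a step that the two limits leave unreadable from compound 1 to compound 3 and a step that the two limits leave unreadable from compound 2 to compound 3, are all left unreadable by the two limits, so none of them shows a size.

Compound 4 `Cc1cn([C@@H]2C[C@H](O)[C@@H](CNC(=O)Nc3ccc(Cl)c(C(F)(F)F)c3)O2)c(=O)[nH]c1=O` keeps the chloro group of compound 1 and differs by trifluoromethyl in place of hydrogen on an aromatic carbon. The measured steps bear on it only in that every change of the group on this ring has so far left the reading at the limit. No step beyond the scatter is therefore expected in this assay, in either direction, and it is expected that compound 4 will most likely again be reported only as a limit. Compound 4 is estimated at 50000 nM, with a range from 15000 nM to 150000 nM, which means an expected step of a number no higher from compound 1 to compound 4 (the limit leaves the size open).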

Compound 4, half-maximal cytotoxic concentration: > 50000 nM
Compound 4: no number, only a limit (the forecaster's own chance of this, stated with the estimate: 75%); the middle value lies on the limit itself.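

In this assay compound 4 gives > 50000 nM, which is a limit, so no step from compound 1 to compound 4 can be read: the limit of > 50000 nM in this assay, at which 4 of the 4 values shown sit.

The compounds shown leave open at what concentration any of them would reach the half-maximal cytotoxic effect, and whether changes on this aromatic ring alter it.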